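The source may report more compounds than this note shows. Statements on the series, on what has been measured and on what is new or still open speak of the compounds shown alone.

Compound 1 `Cc1nn(C)c(C)c1-c1ccc(-c2nnc(N(C)Cc3ccc4nccn4c3)o2)cc1` gives 3160 nM in an assay on COS-7 cells for inhibition of tyrosine-protein kinase receptor UFO (Homo sapiens), read by ELISA, with a stated time of 1 h; on this read-out higher numbers stand for weaker inhibition and lower numbers for stronger inhibition.
Compound 2 `COc1cc(-c2c(C)nn(C)c2C)ccc1-c1nnc(N(C)Cc2ccc3nccn3c2)o1` gives 2000 nM in this assay.
Compound 3 `Cc1cc(-c2c(C)nn(C)c2C)cnc1-c1nnc(N(C)Cc2ccc3ncc(-c4cnn(CCN(C)C)c4)n3c2)o1` gives 1000 nM in this assay.

Among these three, compound 3 has the lowest number in this assay; the gap to compound 2 lies within the scatter, while the gap to compound 1 lies beyond it. Compound 4 `Cc1cc(-c2c(C)nn(C)c2C)cnc1-c1nnc(N(C)Cc2ccc3ncc(-c4ccc(CN(C)C)cn4)n3c2)o1` differs from compound 3 in one place: 5-((dimethylamino)methyl)pyridin-2-yl in place of 1-(2-(dimethylamino)ethyl)-1H-pyrazol-4-yl on an aromatic carbon. Among the compounds with values here, the only measured step, a 1.6-fold lower number from compound 1 to compound 2 (0.20 log units; within the scatter), concerns a different position on the shared core and a different kind of change, so it does not bear on this swap. Nothing measured here speaks for a shift in either direction. Compound 4 is therefore expected to stay close to compound 3, with an estimated step of no change at the digits printed from compound 3 to compound 4 (within the scatter). The estimate for compound 4 is 1000 nM, in a range from 400 nM to 2500 nM.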

Compound 4, half-maximal inhibitory concentration: 126 nM
Estimate against measurement, compound 4: 7.9-fold (0.90 log units) above; the whole stated range lies above it.
By their numbers in this assay, from the lowest: compound 4; then compounds 3, 2 and 1 (each within the scatter of the next, the first and the last beyond it).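

At the aromatic carbon of the five-membered ring in the fused system, 5-((dimethylamino)methyl)pyridin-2-yl in place of 1-(2-(dimethylamino)ethyl)-1H-pyrazol-4-yl gives a 7.9-fold lower number from compound 3 to compound 4 (0.90 log units; beyond the scatter) in this assay. Within the data shown here, this is the first step at this position, and it shows that the number responds to the group placed there. The data offer no evidence on why it moved.

The swap alters ring and chain together, so the compounds shown cannot separate the two. On these data alone, whether a phenyl ring in place of the pyridine ring, or a morpholine in place of the dimethylamino group, would keep the number of compound 4 stays open.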